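The compounds below may be only part of what the source reports. "The series", "measured", "known", "first", "only" and "open" are said of these compounds alone.

Measured in a functional assay on A549 cells (Homo sapiens) for antiproliferative activity, read by MTT assay; a higher number here means a weaker inhibitor, a lower number a stronger inhibitor:
- Compound 1 `CC1(C)CCc2c(ccc(C(=O)/C=C/c3ccc(OCc4cn(-c5ccc(Cl)cc5)nn4)cc3)c2O)O1`: "not active" (no number reported)
- Compound 2 `CC(=O)c1ccc(-n2cc(COc3ccc(/C=C/C(=O)c4ccc5c(c4O)CCC(C)(C)O5)cc3)nn2)cc1`: 149000 nM
- Compound 3 `CCc1ccccc1-n1cc(COc2ccc(/C=C/C(=O)c3ccc4c(c3O)CCC(C)(C)O4)cc2)nn1`: 112000 nM

For the measured compounds named here, compound 3 stands level with compound 2, the only other compound with a number, and compound 1 gave no number at all. The next compound, compound 4 `CCCCCCCCn1cc(COc2ccc(/C=C/C(=O)c3ccc4c(c3O)CCC(C)(C)O4)cc2)nn1`, has octyl in place of 2-ethylphenyl on an aromatic nitrogen of the shared core: octyl in place of 2-ethylphenyl on an aromatic nitrogen.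

Going by the values given here, only one measured step bears on this change, and it also replaces one group on that nitrogen with another: a 1.3-fold lower number from compound 2 to compound 3 (0.12 log units; within the scatter). Among the compounds with values here, that step is small, but both of its groups contain a ring, whereas octyl has none, so the series offers no direct precedent. With so little to go on, no shift beyond the scatter is expected in this assay, and neither direction is favoured. The expected change is a 1.1-fold lower number from compound 3 to compound 4 (0.05 log units; within the scatter). Compound 1, recorded as "not active" (no number reported), shows that a result without a number remains possible. For compound 4 the estimated value is 100000 nM, with an expected range from 35000 nM to 250000 nM.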

Compound 4, half-maximal inhibitory concentration: "not active" (no number reported)
For compound 4 the study gives words and no number; the estimate stays without a comparison.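

For the compounds shown here, compound 3 gives 112000 nM in this assay but compound 4 gives "not active" (no number reported) so no step between compound 3 and compound 4 can be read. The compounds shown leave open how far octyl in place of 2-ethylphenyl shifts the number. No further evidence bears on this result.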